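A few compounds are considered here, and "the series" means these few. Any claim that something is new, unique, unknown or untested is made for them only; others in the source may bear on it.

Going by the values given here, in a functional assay on MDA-MB-231 cells (Homo sapiens) for antiproliferative activity, read by sulforhodamine B assay, with a stated time of 48 h (a lower number here means a stronger inhibitor of growth, a higher number a weaker inhibitor of growth), compound 1 `O=C1COc2ccccc2N1CCCn1cc(-c2ccccc2)nn1` gives 4900 nM, the lower of the two numbers measured so far, while compound 2 `COc1ccc(-c2cn(CCCN3C(=O)COc4ccccc43)nn2)cc1` gives 41500 nM. Compound 3 `O=C1COc2ccccc2N1CCCn1cc(-c2cccnc2)nn1` has not yet been measured. It departs from compound 1 as follows: pyridin-3-yl in place of phenyl on an aromatic carbon. In words, it carries pyridin-3-yl in place of phenyl on an aromatic carbon. Among the compounds with values here, the one measured step that bears on this is an 8.5-fold higher number from compound 1 to compound 2 (0.93 log units; beyond the scatter), which also alters that phenyl, though with methoxy in place of hydrogen on an aromatic carbon. A single step with a different group is a thin guide. With compound 2 at 41500 nM as the only reference, a smaller step in the same direction is expected in this assay, towards a higher number. The estimated step is a 2.2-fold higher number from compound 1 to compound 3 (0.35 log units; beyond the scatter). For compound 3 the expected value is 11000 nM, with an estimated range from 3000 nM to 40000 nM.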

Compound 3, concentration for 50% growth inhibition: 3000 nM
Compound 3: middle estimate off by 3.7-fold (0.56 log units), on the high side; the measured number falls inside the stated range.
By their numbers in this assay, from the lowest: compounds 3 and 1 (each within the scatter of the next); then compound 2.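

In this assay, the change from phenyl to pyridin-3-yl gives a 1.6-fold lower number from compound 1 to compound 3 (0.21 log units; within the scatter), so this position accepts a ring nitrogen and a hydrogen-bond acceptor without a change that can be told from the scatter. The other comparison gives a 14-fold lower number from compound 2 to compound 3 (1.14 log units; beyond the scatter), which shows that the ring on the triazole-type carbon is not sensitive to every change: among these three compounds, only the 4-methoxyphenyl of compound 2 stands apart. No measurement here explains this difference between the groups.

As far as these compounds go, it remains open whether pyridin-2-yl or pyridin-4-yl would match pyridin-3-yl, which would show whether the place of the ring nitrogen matters. From the compounds shown here alone, it is equally open whether a small group such as fluorine, or an amine or a carboxylic acid on the phenyl, would behave like methoxy.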